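The compounds below may be only part of what the source reports. "The series", "measured", "known", "first", "only" and "open" are said of these compounds alone.

Compound 2 `COc1cc2nc(N3CCN(S(=O)(=O)c4cc(F)c(Cl)c(C(=O)O)c4)CC3)nc(N)c2cc1OC` gives the highest number of the two measured compounds in a functional assay on PC-3 cells (Homo sapiens) for inhibition (a lower number here means a stronger inhibitor, a higher number a weaker inhibitor), at 56000 nM; its nearest neighbour, compound 1 `COc1cc2nc(N3CCN(S(=O)(=O)c4ccc(C(C)(C)C)cc4)CC3)nc(N)c2cc1OC`, gives 4100 nM in this assay. Among the compounds with values here, the single measured step, a 14-fold higher number from compound 1 to compound 2 (1.14 log units; beyond the scatter), accompanies the exchange of 4-(tert-butyl)phenyl for 3-carboxy-4-chloro-5-fluorophenyl on the sulfonyl sulfur. Compound 3 `COc1cc2nc(N3CCN(S(=O)(=O)c4ccc(-c5ccccc5)cc4)CC3)nc(N)c2cc1OC` remains to be measured in this assay. It differs from compound 2 by 4-phenylphenyl in place of 3-carboxy-4-chloro-5-fluorophenyl on a sulfonyl sulfur, so the carboxy-bearing ring leaves again and a ring without hydrogen-bond donor or acceptor enters, as in compound 1. Within the data shown here, only that one step bears on this change, and it was large. Because a 14-fold higher number from compound 1 to compound 2 (1.14 log units; beyond the scatter) accompanied the entry of the carboxy-bearing ring, its exit is expected to reverse that step, an estimated 14-fold lower number from compound 2 to compound 3 (1.15 log units; beyond the scatter). Compound 3 is therefore expected to give about 4000 nM in this assay, within a range of 1300 nM to 13000 nM.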

Compound 3, half-maximal inhibitory concentration: 4200 nM
Estimate against measurement, compound 3: 1.1-fold (0.02 log units) below, and the stated range covers the measured number.
By their numbers in this assay, from the lowest: compounds 1 and 3 (each within the scatter of the next); then compound 2.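

In this assay 4-phenylphenyl in place of 3-carboxy-4-chloro-5-fluorophenyl on the sulfonyl sulfur gives a 13-fold lower number from compound 2 to compound 3 (1.12 log units; beyond the scatter) and so the high number of compound 2 now stands against two different partners, not one. Phenyl in place of tert-butyl on an aromatic carbon gives a 1.0-fold higher number from compound 1 to compound 3 (0.01 log units; within the scatter) and this aromatic carbon therefore carries either group with no readable change in the number. No measurement of any property or other data accounts for these steps.

The carboxy, chloro and fluoro groups occur together only in compound 2, so the compounds shown cannot separate their contributions to the higher number. A ring bearing only a carboxylic acid, or only chlorine and fluorine, would separate them, and an amine on the ring would test another kind of group.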